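Methoxy for methyl across two cores

The source may hold more compounds than are shown below. What is called first, only, known or untested is meant among the compounds shown, and "the series" means these compounds.

Compound 1 `Cc1cccc(-c2cc(C(C)(C)C)cc(C(C)C)c2CO)c1` and compound 2 `COc1cccc(-c2cc(C(C)(C)C)cc(C(C)C)c2CO)c1` share one core. In a functional assay on RKE cells for antagonist activity at Vasoactive intestinal polypeptide receptor 1 (Rattus norvegicus), read by HTRF and cAMP accumulation, with stated times of 10 min and 30 min (a higher number here means a weaker inhibitor, a lower number a stronger inhibitor), compound 1 gives 240 nM, and compound 2 gives 200 nM. The step between them, (methoxy in place of methyl on an aromatic carbon), shows as a 1.2-fold lower number from compound 1 to compound 2 (0.08 log units; within the scatter).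

Compound 3 `Cc1cccc(CCC(=O)Nc2sc3c(c2C#N)CCCC3)c1` carries a different core; how it differs from the core of compound 1 is not broken down here. In this assay compound 3 gives 750 nM, the highest of the three numbers, with its steps to compound 1 and to compound 2 both beyond the scatter, so compound 3 is the weakest inhibitor of the measured set.

Compound 4 `COc1cccc(CCC(=O)Nc2sc3c(c2C#N)CCCC3)c1` is not yet measured. Relative to compound 3 it carries methoxy in place of methyl on an aromatic carbon, the same change that takes compound 1 to compound 2, at a place described in the same words.

Among the measured compounds shown here, on that single precedent the expected step is a 1.2-fold lower number from compound 3 to compound 4 (0.06 log units; within the scatter), set beside a 1.2-fold lower number from compound 1 to compound 2 (0.08 log units; within the scatter); it rests only on that one pair and on the change being the same, and the core of compound 3 has no second example of its own. For compound 4 the estimate in this assay is 650 nM, expected to fall between 300 nM and 1400 nM.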

Compound 4, half-maximal inhibitory concentration: 610 nM
Compound 4: middle estimate off by 1.1-fold (0.03 log units), on the high side; measured number inside the range.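

In this assay, methoxy in place of methyl on the core of compound 3 reads as a 1.2-fold lower number from compound 3 to compound 4 (0.09 log units; within the scatter), so on this core the change gives no difference that can be told apart from repeat measurement. Set beside the same change on the core of compound 1, the two steps agree: the same change on two cores in this assay, a 1.2-fold lower number (0.08 log units; within the scatter) from compound 1 to compound 2 and a 1.2-fold lower number (0.09 log units; within the scatter) from compound 3 to compound 4, 1.0-fold (0.01 log units) apart, within the scatter of two such steps. This shows that the change reads alike on these two cores, but only as a step within the scatter on both, so what carries over is the absence of a measurable effect, not a gain in potency, and two pairs say nothing about a third core or another place on the aromatic ring.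

The compounds shown leave open whether a different group at this place on the ring, such as a chlorine, a hydroxyl, an amine or a longer ether chain like ethoxy, would separate from methyl and methoxy on either core. Also open, from the compounds shown here alone, is what a carboxylic acid in place of the nitrile on the core of compound 3 would do.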